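Working notes on the anilide series: compound 4

The source may hold more compounds than are shown below. What is called first, only, known or untested is meant among the compounds shown, and "the series" means these compounds.

The series shares one core; compound 1 `CCc1cccc(NC(=O)CN2CCC(c3cccc[n+]3[O-])CC2)c1`, compound 2 `Cc1cc(C)cc(NC(=O)CN2CCC(c3cccc[n+]3[O-])CC2)c1` and compound 3 `O=C(CN1CCC(c2cccc[n+]2[O-])CC1)Nc1cc(Cl)cc(Cl)c1` differ only in the aryl group on the amide nitrogen. In a functional assay on HEK293 cells for agonist activity at D(4) dopamine receptor (Homo sapiens), read by FLIPR (on this read-out lower numbers stand for smaller maximal responses and higher numbers for larger maximal responses), compound 1 gives 62%, compound 2 gives 76% and compound 3 gives 68%. Among the three, compound 3 stands second highest, within the scatter of both others. The measured steps are a number 14 percentage points higher from compound 1 to compound 2 (beyond the scatter), a number 6 percentage points higher from compound 1 to compound 3 (within the scatter) and a number 8 percentage points lower from compound 2 to compound 3 (within the scatter). Compound 4 `O=C(CN1CCC(c2cccc[n+]2[O-])CC1)Nc1cccc(Cl)c1Cl` is compound 3 with 2,3-dichlorophenyl in place of 3,5-dichlorophenyl on an amide-type nitrogen. Within the data shown here, no measured step moves a chlorine around the ring, so none bears directly on this change; the two aryl swaps that end at compound 3 both stayed within the scatter. Accordingly the expectation is a number 2 percentage points lower from compound 3 to compound 4 (within the scatter), with no direction beyond the scatter. Compound 4 is estimated at 66%, in the range 50% to 82%.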

Compound 4, largest response reached (reported as efficacy), in percent of the reference or control that the assay uses: 66%
Compound 4: the middle estimate sits on the measured number at the digits printed; the measured number falls inside the stated range.
By their numbers in this assay, from the lowest: compounds 1, 4, 3 and 2 (each within the scatter of the next, the first and the last beyond it).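

Moving the chlorines, with 2,3-dichlorophenyl in place of 3,5-dichlorophenyl on the amide-type nitrogen, gives the first step that changes only their placement (a number 2 percentage points lower from compound 3 to compound 4 (within the scatter)). Compound 4 also stays within the scatter of both other anilides (a number 10 percentage points lower from compound 2 to compound 4 (within the scatter); a number 4 percentage points higher from compound 1 to compound 4 (within the scatter)). Nothing available accounts for this result. Open, going by these compounds, is how a phenyl carrying a single chlorine, a methoxy group or a trifluoromethyl group would read on the shared core. Also open, on these data alone, is whether any other aryl group on the amide-type nitrogen falls beyond the scatter of compound 4.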